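The compounds below may be only part of what the source reports. "The series", "measured", "known", "first", "only" and "open" are said of these compounds alone.

Measured compounds and their values:

- compound 1, `CC(C)c1ccc(NC(=O)N[C@H](C)c2ccccc2)cc1`: 99%
- compound 2, `CC(C)c1ccc(NC(=O)N[C@@H](C)c2ccccc2)cc1`: 98%
- compound 3, `CCCCCc1ccc(NC(=O)N[C@@H](C)c2ccccc2)cc1`: 98%

All three numbers come from an ADME assay on the whole organism with Oryza sativa as the target, tested at 0.1 uM; a higher number here means a weaker effect of the compound at the concentration tested, a lower number a stronger effect. Compound 1 has the highest of the three numbers, but the gaps are small: the nearest, compound 2, sits a number 1 percentage points lower from compound 1 to compound 2 (within the scatter), and compound 3 sits at the same distance, so none of the three can be told apart by this assay. The step from compound 1 to compound 2 is a change in configuration only, because of the fact that compounds 1 and 2 differ only in the configuration as drawn; it leaves the number essentially where it was. The step from compound 2 to compound 3 swaps the group on the aromatic carbon, pentyl in place of isopropyl, and gives no change at the digits printed from compound 2 to compound 3 (within the scatter).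

Compound 4, `CCCCCCc1ccc(NC(=O)N[C@H](C)c2ccccc2)cc1`, has not yet been measured. It differs from compound 1 by hexyl in place of isopropyl on an aromatic carbon. For the measured compounds named here, this is the same kind of change as the one from compound 2 to compound 3, a longer chain in place of isopropyl on the same aromatic carbon, and that step stayed within the scatter. The expectation for compound 4 in this assay is therefore a number close to that of compound 1: the step from compound 1 to compound 4 is expected to be a number 1 percentage points lower from compound 1 to compound 4 (within the scatter). Compound 4 is estimated at 98%, with a range from 93% to 100%.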

Compound 4, a percentage reported as activity, at one concentration (the size of the read-out at that concentration, not a potency): 100%
Compound 4: the middle estimate sits 2 percentage points below what was measured; measured number inside the range.
By their numbers in this assay, from the lowest: compounds 2, 3, 1 and 4 (each within the scatter of the next).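

In this assay, hexyl in place of isopropyl on the aromatic carbon gives a number 1 percentage points higher from compound 1 to compound 4 (within the scatter). For the compounds shown here, the earlier chain swap, pentyl in place of isopropyl, was seen only with the configuration of compound 2, so this step adds the first reading with the configuration of compound 1, and there too a longer unbranched chain at this position leaves the read-out within the scatter. Nothing available explains why the number stays put at this position when the chain changes, and no measured property bears on this step.

These compounds carry only hydrocarbon chains at this position, so they leave open whether an amine, a carboxylic acid or a chain longer than hexyl would move the number beyond the scatter. On these data alone, because the read-out comes from a single concentration and all four compounds lie within the scatter of their neighbours, it also remains open whether any of these changes would show a difference at a higher concentration.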